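Removing the tetramethylpiperidinyloxy group from compound 3

The source may report more compounds than this note shows. Statements on the series, on what has been measured and on what is new or still open speak of the compounds shown alone.

Compound 3 `CCOC(=O)[C@@H]1C(=O)N(Cc2ccccc2)C[C@@H](ON2C(C)(C)CCCC2(C)C)[C@H]1c1ccc(F)cc1` is the fluoro analogue of compound 1 `CCOC(=O)[C@@H]1C(=O)N(Cc2ccccc2)C[C@@H](ON2C(C)(C)CCCC2(C)C)[C@H]1c1ccccc1`. Within the data shown here, in a physicochemical assay, with a stated time of 60 min (a higher number here means a weaker inhibitor, a lower number a stronger inhibitor), compound 3 gives 15900 nM, the higher of the two numbers measured so far; the nearest is compound 1 with 12300 nM, and a 1.3-fold higher number from compound 1 to compound 3 (0.11 log units; within the scatter). Compound 2 `CCOC(=O)[C@@H]1C(=O)N(Cc2ccccc2)C[C@@H](O)[C@H]1c1ccccc1` reaches only the limit of the assay, in this assay compound 2 gives > 100000 nM. Compound 4 `CCOC(=O)[C@@H]1C(=O)N(Cc2ccccc2)C[C@@H](O)[C@H]1c1ccc(F)cc1` has not yet been measured.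

Compound 4 differs from compound 3 in one place: hydrogen in place of 2,2,6,6-tetramethylpiperidin-1-yl on an oxygen on a saturated carbon. On these data alone, the same change has been measured once, from compound 1 to compound 2, where an at least 8.1-fold higher number from compound 1 to compound 2 (0.91 log units; beyond the scatter); that step ends at the limit of > 100000 nM in this assay, at which 1 of the 3 values shown sits, so its true size is unknown and may be larger than the figure shows. Because a 1.3-fold higher number from compound 1 to compound 3 (0.11 log units; within the scatter) lies within the scatter, the fluoro substituent gives no reason to expect a different response, and the loss of the tetramethylpiperidinyl group is expected to weaken inhibition at least as much as before, a 9.4-fold higher number from compound 3 to compound 4 (0.97 log units; beyond the scatter). Compound 4 is therefore expected to sit at or beyond the limit of this assay, estimated at 150000 nM with a range from 60000 nM to 400000 nM. A reported limit rather than a number is the more likely outcome for compound 4.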

Compound 4, half-maximal inhibitory concentration: > 100000 nM
Compound 4: a limit, no number; the forecaster's own chance of this, stated with the estimate: 80%; the middle value lies beyond the limit too.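

In this assay, the change from (2,2,6,6-tetramethylpiperidin-1-yl)oxy to hydroxy now reads the same way in the fluoro pair, with an at least 6.2-fold higher number from compound 3 to compound 4 (0.79 log units; beyond the scatter), as in the unsubstituted pair, with an at least 8.1-fold higher number from compound 1 to compound 2 (0.91 log units; beyond the scatter). The weakening on this oxygen on a saturated carbon is therefore not confined to a single pair: it appears with and without the fluoro substituent, and neither compound 1 nor compound 3 goes against it. Compound 2 and compound 4 are both limits and not numbers, and the step between them cannot be read: the limit of > 100000 nM in this assay, at which 2 of the 4 values shown sit.

On these data alone, how far either hydroxy compound lies past the limit remains open, and so does any effect of the fluoro substituent once the 2,2,6,6-tetramethylpiperidin-1-yl group has left. Also open, as far as these compounds go, is how much of the inhibition seen for compound 1 at 12300 nM and compound 3 at 15900 nM would remain with a piperidin-1-yl group lacking the four methyl groups, or with a benzyl group, on the same oxygen.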